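The source may report more compounds than this note shows. Statements on the series, on what has been measured and on what is new or still open speak of the compounds shown alone.

Measured so far in a functional assay on HBL-100 cells (Homo sapiens) for inhibition, read by sulforhodamine B assay, with a stated time of 48 h; a higher number here means a weaker inhibitor of growth, a lower number a stronger inhibitor of growth:

compound 1, `COC(=O)[C@@]1(C)CC[C@@H]2C3=C1CC[C@@H](C)[C@]3(C)C[C@@H]1c3cc(Br)ccc3N[C@H]21`, gives 34000 nM
compound 2, `COC(=O)[C@@]1(C)CC[C@@H]2C3=C1CC[C@@H](C)[C@]3(C)C[C@@H]1c3cc(OC)ccc3N[C@H]21`, gives 15000 nM
compound 3, `COC(=O)[C@@]1(C)CC[C@@H]2C3=C1CC[C@@H](C)[C@]3(C)Cc1c2[nH]c2ccc(Br)cc12`, gives 16000 nM

Compounds 1 and 2 share one core and differ in a single place: methoxy in place of bromo on an aromatic carbon. That change gave a 2.3-fold lower number from compound 1 to compound 2 (0.36 log units; beyond the scatter).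

Compound 3 sits on a different core; the difference between the two cores is not broken down here. The numbers for compound 3 and compound 2 lie within the scatter of each other, so nothing can be said about their order. Against compound 1, the number for compound 3 is lower, and that gap is beyond the scatter.

Compound 4, `COC(=O)[C@@]1(C)CC[C@@H]2C3=C1CC[C@@H](C)[C@]3(C)Cc1c2[nH]c2ccc(OC)cc12`, is not yet measured. It stands to compound 3 as compound 2 stands to compound 1: methoxy in place of bromo on an aromatic carbon. The place lines of the two changes read the same word for word, so this is the same change on the second core. Among the compounds shown, the change occurs twice in all, and only the first instance carries a measurement.

The expectation for compound 4 rests on that one measured instance. Among the compounds with values here, the step from compound 1 to compound 2 was modest, and the same size of step is expected here, with wider bounds because only one example supports it. For compound 4 the expected number in this assay is 7000 nM, estimated to fall between 3500 nM and 16000 nM. The step this estimate implies is a 2.3-fold lower number from compound 3 to compound 4 (0.36 log units; beyond the scatter), resting on a 2.3-fold lower number from compound 1 to compound 2 (0.36 log units; beyond the scatter).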

Compound 4, concentration for 50% growth inhibition: 5000 nM
Estimate against measurement, compound 4: 1.4-fold (0.15 log units) above, within the range that was stated.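

In this assay, methoxy in place of bromo on an aromatic carbon gives a 3.2-fold lower number from compound 3 to compound 4 (0.51 log units; beyond the scatter), so the lowering seen on the core of compound 1 appears again on the core of compound 3. Within the data shown here, the two steps run in the same direction, and the gap between them gives no ground for calling the change larger on either core: the same change on two cores in this assay, a 2.3-fold lower number (0.36 log units; beyond the scatter) from compound 1 to compound 2 and a 3.2-fold lower number (0.51 log units; beyond the scatter) from compound 3 to compound 4, 1.4-fold (0.15 log units) apart, within the scatter of two such steps This supports carrying the change between these two cores in this growth read-out, but it rests on only two matched pairs, does not extend to any other core or cell line, and does not show what produces the lowering.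

The compounds shown compare only bromo and methoxy at this place, leaving open whether hydroxy, an amine or a nitrile there would continue the trend or break it. Also open is whether the step would hold with a carboxylic acid or an amide in place of the methyl ester, a part that stays the same across all the compounds shown.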